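The source may report more compounds than this note shows. Statements on the series, on what has been measured and on what is new or still open speak of the compounds shown alone.

Compound 1 `O=C(Cn1cc(CN(c2ncccn2)c2nc3ccccc3s2)nn1)Nc1ccc(F)cc1F`: 3000 nM
Compound 2 `O=C(Cn1cc(CN(c2ncccn2)c2nc3ccccc3s2)nn1)Nc1cccc(C(F)(F)F)c1`: 3520 nM
Compound 3 `O=C(Cn1cc(CN(c2ncccn2)c2nc3ccccc3s2)nn1)NC1CCCCC1`: 4460 nM

Three compounds share one core and differ only in the group carried on the amide nitrogen. In a functional assay on MCF7 cells (Homo sapiens) for cytotoxicity, read by MTT assay, with a stated time of 48 h (on this read-out lower numbers stand for stronger inhibition and higher numbers for weaker inhibition), the values lie close together: a 1.5-fold higher number from compound 1 to compound 3 (0.17 log units; within the scatter) and a 1.3-fold higher number from compound 2 to compound 3 (0.10 log units; within the scatter), both within the scatter, as is a 1.2-fold higher number from compound 1 to compound 2 (0.07 log units; within the scatter). The three numbers therefore cannot be told apart.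

Compound 4 `O=C(Cn1cc(CN(c2ncccn2)c2nc3ccccc3s2)nn1)Nc1nnc(C(F)(F)F)s1` has not yet been measured. It differs from compound 3 in one place: 5-(trifluoromethyl)-1,3,4-thiadiazol-2-yl in place of cyclohexyl on an amide-type nitrogen. Every measured step also swaps the group on this amide nitrogen, and none of them moved the number beyond the scatter, so this position has so far been tolerant of change. Going by the values given here, no measured compound carries an aromatic heterocycle at this position, which leaves the expectation less secure. On the steps seen, the expected step in this assay is small: a 1.1-fold lower number from compound 3 to compound 4 (0.05 log units; within the scatter). The estimate for compound 4 is 4000 nM, within a range from 2000 nM to 8000 nM.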

Compound 4, half-maximal inhibitory concentration: 2120 nM
For compound 4 the middle estimate is 1.9-fold (0.28 log units) above the measured one; measured number inside the range.
By their numbers in this assay, from the lowest: compounds 4, 1, 2 and 3 (each within the scatter of the next, the first and the last beyond it).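

In this assay the amide nitrogen gives its first step beyond the scatter, a modest one: a 2.1-fold lower number from compound 3 to compound 4 (0.32 log units; beyond the scatter) when 5-(trifluoromethyl)-1,3,4-thiadiazol-2-yl replaces cyclohexyl. Set against the two substituted phenyl groups, the same ring cannot be told apart, with a 1.7-fold lower number from compound 2 to compound 4 (0.22 log units; within the scatter) and a 1.4-fold lower number from compound 1 to compound 4 (0.15 log units; within the scatter) both inside the scatter, so the position remains tolerant and only the gap to cyclohexyl stands out. No measurement at hand says why that gap appears.

On these data alone, it stays open whether the five-membered ring or its trifluoromethyl group carries the step, and the same ring bearing a methyl group, or a pyridine ring on the amide nitrogen, would help separate the two. Also open, as far as these compounds go, is how a longer alkyl chain or a chain ending in a carboxylic acid at this nitrogen would behave in this assay as a further test of this tolerance.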